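The source may hold more compounds than are shown below. What is called first, only, known or untested is meant among the compounds shown, and "the series" means these compounds.

Measured so far in an ADME assay on microsomes from liver (Mus musculus) for metabolic stability, read by LC-MS, using NADPH, with stated times of 10 min and 30 min; a lower number here means slower removal, a higher number faster removal of the compound:
compound 1 `CC[C@@H]1c2cc(Cl)ccc2C(=O)N1c1cncc2c1CCC[C@H]2NC(C)=O` with < 20.2 mL/min/kg
compound 2 `CCC(=O)N[C@@H]1CCCc2c1cncc2N1C(=O)c2ccc(Cl)cc2[C@H]1CC` with 44.9 mL/min/kg

Compound 1 sits at the lower limit of this assay, (the limit of < 20.2 mL/min/kg in this assay, at which 1 of the 2 values shown sits), so for compound 1 only a bound and no number is known. Compound 2 gives a number in this assay, 44.9 mL/min/kg. For the measured compounds named here, the one measured step, an at least 2.2-fold higher number from compound 1 to compound 2 (0.34 log units; beyond the scatter), concerns a methyl in place of hydrogen on a saturated chain carbon bound to a carbonyl carbon and does not touch the change considered here.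

Compound 3 `CC[C@H]1c2cc(Cl)ccc2C(=O)N1c1cncc2c1CCC[C@H]2NC(C)=O` is still to be measured. It relates to compound 1 as follows: the two compounds have the same atoms and bonds and differ only in configuration as drawn: 1 of 2 stereo elements differ; a stereocentre at a saturated ring carbon is drawn R in compound 1 and S in compound 3. Going by the values given here, no measured step covers a change of configuration alone, so no direction beyond the scatter can be drawn from the data. Compound 3 is therefore expected to give 20 mL/min/kg, within the range 9 mL/min/kg to 45 mL/min/kg. The expected step that the limit leaves unreadable from compound 1 to compound 3 is estimated to stay within the scatter, with a fair chance that again only a limit is reported.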

Compound 3, clearance: < 20.2 mL/min/kg
Compound 3: no number, only a limit; the forecaster's own chance of this, stated with the estimate: 40%; the middle value lies beyond the limit too.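

In this assay compound 3 gives < 20.2 mL/min/kg, which is a limit and not a number. For the compounds shown here, compound 1 also carries only a limit, so no step from compound 1 to compound 3 can be read: the limit of < 20.2 mL/min/kg in this assay, at which 2 of the 3 values shown sit. The compounds shown leave open whether the two configurations differ in clearance at all.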